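Ring Size on the Amide Nitrogen of a Quinolinol Urea

The source may report more compounds than this note shows. Statements on the series, on what has been measured and on what is new or still open speak of the compounds shown alone.

Measured compounds:
compound 1, `O=C(NCCCOc1ccc2nc(O)ccc2c1)N(C1CC1)[C@@H]1CCCCC[C@H]1O`, 44% in a functional assay on the whole organism for inhibition, with Mus musculus as the target, at a dose of 30 mg/kg by the oral route; a higher number here means more inhibition at the dose given (going by the name of the read-out), a lower number less inhibition
compound 2, `O=C(NCCCOc1ccc2nc(O)ccc2c1)N(C1CCCC1)[C@H]1CCCC[C@@H]1O`, 78%

Compound 2 stands highest of the two numbers in this assay, and compound 1 sits a long way below it, beyond the scatter. Compound 3, `O=C(NCCCOc1ccc2nc(O)ccc2c1)N(C1CCCCCCC1)[C@H]1CCCC[C@@H]1O`, keeps the core of compound 2 and differs in one place: cyclooctyl in place of cyclopentyl on an amide-type nitrogen. Within the data shown here, no measured pair shows this change alone, so its size is unknown. The expectation for compound 3 is a small step, a number 10 percentage points lower from compound 2 to compound 3 (within the scatter), not clearly beyond the scatter. Compound 3 is therefore estimated at 68%, within a range from 40% to 90%.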

Compound 3, a percentage reported as inhibition, in the whole organism at one dose (the size of the read-out at that dose, not a potency): 100%
Estimate against measurement, compound 3: 32 percentage points below, outside the stated range (above it).
By their numbers in this assay, from the lowest: compound 1; then compound 2; then compound 3.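

In this assay, cyclooctyl in place of cyclopentyl on the amide-type nitrogen gives a number 22 percentage points higher from compound 2 to compound 3 (beyond the scatter) with the rest of the molecule unchanged. This position therefore accepts a much larger carbon ring without any loss of inhibition at the dose given, and ring size here clearly moves the read-out. Nothing available explains why the larger ring gives the higher number. Still open, from the compounds shown here alone, is whether inhibition climbs steadily through cyclohexyl and cycloheptyl, and whether an open octyl chain or a ring containing nitrogen, such as piperidinyl, would serve as well as cyclooctyl.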